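Methoxy groups on a compound at the assay limit

A few compounds are considered here, and "the series" means these few. Any claim that something is new, unique, unknown or untested is made for them only; others in the source may bear on it.

Compound 1 `COc1ccc(C2=N/C(=C\c3cc(Br)cc(Br)c3OC(C)=O)C(=O)NN2c2ncc(-c3ccccc3)s2)cc1OC` gives 4330 nM
Compound 2 `COc1cc(C2=N/C(=C\c3cc(Br)cc(Br)c3OC(C)=O)C(=O)NN2c2ncc(-c3ccccc3)s2)cc(OC)c1OC` gives 410 nM
Compound 3 `CC(=O)Oc1c(Br)cc(Br)cc1/C=C1\N=C(c2ccccc2)n2c(=S)nc(C)n2C1=O` gives > 100000 nM

All three values come from a functional assay on MCF7 cells (Homo sapiens) for antiproliferative activity, read by MTT assay, with a stated time of 48 h (a higher number here means a weaker inhibitor, a lower number a stronger inhibitor), alone. Compound 3 stands at > 100000 nM as a limit, not a number. Compound 4 `COc1ccc(C2=N/C(=C\c3cc(Br)cc(Br)c3OC(C)=O)C(=O)n3c(C)nc(=S)n32)cc1OC` carries 3,4-dimethoxyphenyl in place of phenyl on a carbon with a double bond to nitrogen, as counted in 3,4-dimethoxyphenyl in place of phenyl on a carbon with a double bond to nitrogen for this swap. For the measured compounds named here, the only measured step that adds a methoxy group is an 11-fold lower number from compound 1 to compound 2 (1.02 log units; beyond the scatter) on a different core, and it is large. A sizeable fall in the number is therefore expected in this assay here, though the different core leaves this uncertain. The estimated change is an at least 3.3-fold lower number from compound 3 to compound 4 (0.52 log units; beyond the scatter) in this expectation. Compound 4 is expected at 30000 nM within an estimated range of 4000 nM to 100000 nM in this assay.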

Compound 4, half-maximal inhibitory concentration: 6840 nM
Compound 4: middle estimate off by 4.4-fold (0.64 log units), on the high side, and the stated range covers the measured number.
By their numbers in this assay, from the lowest: compound 2; then compounds 1 and 4 (each within the scatter of the next). At a limit, above all of these: compound 3.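

In this assay, 3,4-dimethoxyphenyl in place of phenyl on a carbon with a double bond to nitrogen gives an at least 14-fold lower number from compound 3 to compound 4 (1.16 log units; beyond the scatter), so on this core the methoxy groups lead from a limit to a readable value. The earlier methoxy step lay on the core of compound 1, and a large fall now appears on both cores, although the two steps add different methoxy groups. Compound 3 stands at a limit, so the true size of this step stays unknown: the limit of > 100000 nM in this assay, at which 1 of the 4 values shown sits.

The compounds shown leave open whether a lone methoxy group would give a similar fall, and whether an amine or a carboxylic acid on that phenyl ring would do the same.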